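Methyl for Hydrogen on the Phenyl of Compound 1

A few compounds are considered here, and "the series" means these few. Any claim that something is new, unique, unknown or untested is made for them only; others in the source may bear on it.

Measured so far:
compound 1, `O=C1CC(c2nc(-c3ccccc3)no2)CN1c1ccccc1`, with 350 nM in an in vitro functional assay on HEK293-A cells for positive allosteric modulation of metabotropic glutamate receptor 5 (Homo sapiens), read by FLIPR and calcium flux; on this read-out lower numbers stand for an effect already at smaller amounts and higher numbers for an effect only at larger amounts of compound
compound 2, `O=c1oc2ccccc2n1Cc1nc(-c2cccc(Cl)c2)no1`, with > 10000 nM in this assay

Within the data shown here, compound 1 holds the only number among the values shown in this assay, where compound 1 gives 350 nM. For compound 2 the assay reports only a limit, > 10000 nM, and the limit of > 10000 nM in this assay, at which 1 of the 2 values shown sits, marks the threshold at which that value sits. Among the measured compounds shown here, no pair of these two compounds differs in a single place, so their values stand side by side without a measured step between them.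

Compound 3, `Cc1ccc(N2CC(c3nc(-c4ccccc4)no3)CC2=O)cc1`, is not yet measured. It differs from compound 1 as follows: methyl in place of hydrogen on an aromatic carbon. For the measured compounds named here, with no measured step of this kind to lean on, the expected step of a 1.2-fold lower number from compound 1 to compound 3 (0.07 log units; within the scatter) is taken as none beyond the usual scatter. Compound 3 is therefore estimated at 300 nM, with a range from 100 nM to 1200 nM.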

Compound 3, half-maximal effective concentration: 384 nM
Estimate against measurement, compound 3: 1.3-fold (0.11 log units) below, and the stated range covers the measured number.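

In this assay, among these compounds, the step of a 1.1-fold higher number from compound 1 to compound 3 (0.04 log units; within the scatter) is the first measured change at this place. It shows that a methyl group can sit on this phenyl, para to a large group, without a difference beyond the scatter. Phenyl and 4-methylphenyl thus cannot be told apart on this read-out, and nothing in the data shown bears on this step.

From the compounds shown here alone, what a chlorine atom, a methoxy group, an amine or a carboxylic acid would do at this place stays open, as does whether a longer chain such as ethyl would give the same reading. The compounds shown also leave open how a methyl group would read at the other carbons of this ring.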